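Sulfonyl Replacement of a Piperidine Amide in Frizzled-Related Binding

This account rests on a few compounds, and the source may have more. Where it says the series, first, only, none or still open, it means among the compounds named here.

Compounds measured so far:
- compound 1, `O=C(c1ccc(C(F)(F)F)cc1)N1CCC(NS(=O)(=O)c2cc(S(=O)(=O)c3ccccc3)ccc2C(F)(F)F)CC1`: 400 nM
- compound 2, `O=S(=O)(NC1CCN(S(=O)(=O)c2ccccc2)CC1)c1cc(S(=O)(=O)c2ccccc2)ccc1C(F)(F)F`: 130 nM

Among the measured compounds shown here, in an assay on isolated protein for displacement of a labelled ligand from secreted frizzled-related protein 1 (Homo sapiens), read by fluorescence polarization, with a stated time of 30 min (a higher number here means a weaker inhibitor, a lower number a stronger inhibitor), compound 1 gives 400 nM, the higher of the two numbers so far; its nearest neighbour is compound 2, which in this assay gives 130 nM. For the measured compounds named here, the single measured step, a 3.1-fold lower number from compound 1 to compound 2 (0.49 log units; beyond the scatter), goes beyond the scatter and comes from exchanging the amide on the ring nitrogen for a sulfonyl.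

Compound 3, `O=C(O)c1ccc(S(=O)(=O)N2CCC(NS(=O)(=O)c3cc(S(=O)(=O)c4ccccc4)ccc3C(F)(F)F)CC2)cc1`, has not yet been measured. It differs from compound 1 as follows: (4-carboxyphenyl)sulfonyl in place of (4-(trifluoromethyl)phenyl)carbonyl on an amine nitrogen in a ring. The change shares its essence with the measured step, a sulfonyl replacing the carbonyl on the ring nitrogen, but the entering ring now carries a carboxy group, for which no measured comparison exists.

Going by the values given here, the only step that bears on this change is a 3.1-fold lower number from compound 1 to compound 2 (0.49 log units; beyond the scatter). On that basis the number for compound 3 is expected to move down by a comparable, modest amount, a 2.2-fold lower number from compound 1 to compound 3 (0.35 log units; beyond the scatter), with the carboxy group adding uncertainty in either direction. The estimate for compound 3 in this assay is therefore 180 nM, within a range from 60 nM to 600 nM.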

Compound 3, half-maximal inhibitory concentration: 20 nM
Estimate against measurement, compound 3: 9.0-fold (0.95 log units) above, and the stated range ends above it.
By their numbers in this assay, from the lowest: compound 3; then compound 2; then compound 1.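

The ring nitrogen tolerates more than a plain phenylsulfonyl group, and a substituent on that aromatic ring can strengthen binding well beyond what the sulfonyl exchange alone gave. In this assay adding carboxy in place of hydrogen on an aromatic carbon gives a 6.5-fold lower number from compound 2 to compound 3 (0.81 log units; beyond the scatter) on top of the earlier step, and the full exchange of (4-(trifluoromethyl)phenyl)carbonyl for (4-carboxyphenyl)sulfonyl gives a 20-fold lower number from compound 1 to compound 3 (1.30 log units; beyond the scatter) overall, so the entering carboxy group accounts for more of the total change than the sulfonyl exchange does. Nothing available here accounts for the gain, so these numbers describe its size and not its origin.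

The compounds shown leave open whether the gain depends on the carboxylic acid itself, which a methyl ester, a primary amide or a tetrazole on the same ring would test. They also leave open whether carboxy would help to the same extent without the sulfonyl, as a (4-carboxyphenyl)carbonyl group on the ring nitrogen would show.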